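Benzyl for phenyl on a chloropyrimidine diamine: growth inhibition

The compounds below may be only part of what the source reports. "The series", "measured", "known", "first", "only" and "open" are said of these compounds alone.

The set rests on a shared diaminopyrimidine core carrying a chlorine. Compound 1, `Cc1ccccc1Nc1nc(Nc2ccccc2)ncc1Cl`, and compound 2, `Cc1ccccc1Nc1nc(NCc2ccccc2)ncc1Cl`, share the core of compound 1 and differ only in benzyl in place of phenyl on a nitrogen on an aromatic ring. Compound 3, `CN1CCN(c2ccc(Nc3ncc(Cl)c(Nc4ccccc4)n3)nc2)CC1`, carries a second core; how the two cores differ is not broken down here. Compound 4, `CN1CCN(c2ccc(Nc3ncc(Cl)c(NCc4ccccc4)n3)nc2)CC1`, is not yet measured and differs from compound 3 by benzyl in place of phenyl on a nitrogen on an aromatic ring, the same change that separates compound 1 from compound 2.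

In an ADME assay on L02 cells (Homo sapiens) for inhibition, read by CCK-8 assay, with a stated time of 48 h (on this read-out lower numbers stand for stronger inhibition of growth and higher numbers for weaker inhibition of growth), compound 1 gives > 100000 nM, which is a limit of the assay and not a number. In this assay compound 2 likewise gives > 100000 nM, again a limit. The step that the two limits leave unreadable from compound 1 to compound 2 therefore cannot be read, because the limit of > 100000 nM in this assay, at which 2 of the 3 values shown sit, hides its size. Among the measured compounds shown here, compound 3 gives 7990 nM in this assay, the only number among the three values.

The one measured case of the same change is left unreadable and gives no direction. For compound 4 the writer therefore expects a small step of a 1.9-fold higher number from compound 3 to compound 4 (0.27 log units; within the scatter). Compound 4 is expected to give 15000 nM in this assay, with a range from 4000 nM to 60000 nM.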

Compound 4, concentration for 50% growth inhibition: 20300 nM
Estimate against measurement, compound 4: 1.4-fold (0.13 log units) below; low and high end bracket the measured number.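

In this assay the change gives a 2.5-fold higher number from compound 3 to compound 4 (0.40 log units; beyond the scatter), so on the core of compound 3, anilino to benzylamino goes with weaker inhibition of growth, by a modest step that lies beyond the usual scatter. On the core of compound 1 the same change cannot be read, and the step there cannot be set beside this one, because the values of both compound 1 and compound 2 are limits of the assay and not numbers: the limit of > 100000 nM in this assay, at which 2 of the 4 values shown sit. The series therefore shows the size and direction of this change on one core only, and it does not show whether the change carries from one core to the other, since a single readable step makes no pattern and does not establish that the two cores respond alike.

The compounds shown leave open what a longer chain on that nitrogen, such as phenethyl in place of benzyl, would do to the number, and whether an amine or a carboxylic acid carried on the benzyl group would shift it in either direction. They also leave open whether phenyl to benzyl would give a step of similar size on a third core.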